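Swapping a pyridine for a pyrimidine on the piperazine arm

This account rests on a few compounds, and the source may have more. Where it says the series, first, only, none or still open, it means among the compounds named here.

Compound 1 `CC1(C)[C@@H]2CC[C@@]1(CS(=O)(=O)N1CCN(c3ccc(Br)cn3)CC1)C(=O)C2`: 1580 nM
Compound 2 `CC1(C)[C@@H]2CC[C@@]1(CS(=O)(=O)NC1CCN(c3ccc(C(F)(F)F)cn3)CC1)C(=O)C2`: 15800 nM

Both compounds were tested in a functional assay on CHO-K1 cells for antagonist activity at C-X-C chemokine receptor type 3 (Homo sapiens), read by FLIPR and calcium flux; on this read-out lower numbers stand for stronger inhibition and higher numbers for weaker inhibition. Compound 1 gives the lower of the two numbers, and compound 2 gives the higher. Compound 3 `CC1(C)[C@@H]2CC[C@@]1(CS(=O)(=O)N1CCN(c3ncc(Br)cn3)CC1)C(=O)C2` has not been measured; it differs from compound 1 by a single change: 5-bromopyrimidin-2-yl in place of 5-bromopyridin-2-yl on an amine nitrogen in a ring. For the measured compounds named here, no measured pair shows this change, so there is nothing to anchor its size. The expectation for compound 3 is a step of a 1.0-fold higher number from compound 1 to compound 3 (0.01 log units; within the scatter), that is, none beyond the scatter. Compound 3 is therefore estimated at 1600 nM, with a range from 500 nM to 5000 nM.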

Compound 3, half-maximal inhibitory concentration: 631 nM
Estimate against measurement, compound 3: 2.5-fold (0.40 log units) above, and the stated range covers the measured number.
By their numbers in this assay, from the lowest: compound 3; then compound 1; then compound 2.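

In this assay, 5-bromopyrimidin-2-yl in place of 5-bromopyridin-2-yl on the ring amine nitrogen gives a 2.5-fold lower number from compound 1 to compound 3 (0.40 log units; beyond the scatter), a modest step that lies beyond the scatter. This position therefore accepts a second ring nitrogen in the aromatic ring, and inhibition gets stronger rather than weaker. Nothing measured here explains the step. Still open, on these data alone, is whether the gain holds with a nitrile or a methoxy group in place of the bromine. A pyrazine ring in this place also remains an open question.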